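The compounds below may be only part of what the source reports. "The series", "measured", "known", "first", "only" and "open" are said of these compounds alone.

Measured compounds in an assay on CHO cells for displacement of a labelled ligand from adenosine receptor A3 (Homo sapiens), read by scintillation counting, tested at 10 uM; on this read-out lower numbers stand for less inhibition and higher numbers for more inhibition at the one concentration tested (going by the name of the read-out):
- compound 1, `CC(C)(C)Cc1csc(N)c1C(=O)c1ccc(Cl)c(Cl)c1`: 10%
- compound 2, `CC(C)(C)Cc1c(-c2ccccc2)sc(N)c1C(=O)c1ccc(Cl)cc1`: 1%
- compound 3, `CC(C)(C)Cc1c(-c2ccccc2)sc(N)c1C(=O)c1cccc(Cl)c1`: 5%

Compound 3 sits second highest of the three numbers in this assay, with compound 2 nearest, a number lower but within the scatter, and compound 1 furthest, a number higher but also within the scatter. None of the three can be called stronger or weaker than another on these readings.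

Among the measured compounds shown here, the one step measured within the set, a number 4 percentage points higher from compound 2 to compound 3 (within the scatter), moves the chloro group around the phenyl on the carbonyl carbon and stays within the scatter. For the measured compounds named here, compound 1 carries the 3,4-dichlorophenyl but lacks the phenyl on the core; no single-place step connects it to compound 3, and its value and that of compound 3 lie within the scatter of each other.

Compound 4, `CC(C)(C)Cc1c(-c2ccccc2)sc(N)c1C(=O)c1ccc(Cl)c(Cl)c1`, is to be measured in this assay. It differs from compound 3 by chloro in place of hydrogen on an aromatic carbon. Going by the values given here, no measured step bears directly on this change; the only neighbouring comparison, the within-scatter step from compound 2 to compound 3, and the closeness of compound 1 to compound 3, give no reason to expect a move beyond the scatter in either direction. The step of a number 3 percentage points higher from compound 3 to compound 4 (within the scatter) is therefore expected to be small. For compound 4 the estimate is 8%, expected between 0% and 20%.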

Compound 4, a percentage reported as inhibition, at one concentration (the size of the read-out at that concentration, not a potency): 6%
The estimate for compound 4 lay 2 percentage points above the measured number; low and high end bracket the measured number.
By their numbers in this assay, from the lowest: compounds 2, 3, 4 and 1 (each within the scatter of the next).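

In this assay, chloro in place of hydrogen on the aromatic carbon ortho to a chloro group and para to a large group, turning 3-chlorophenyl into 3,4-dichlorophenyl, gives a number 1 percentage points higher from compound 3 to compound 4 (within the scatter), and the same change made on the 4-chlorophenyl gives a number 5 percentage points higher from compound 2 to compound 4 (within the scatter), so both single-chloro compounds now have a direct comparison with the 3,4-dichlorophenyl and neither comparison leaves the scatter. The 3,4-dichlorophenyl also gives the first direct reading of phenyl in place of hydrogen on the core, a number 4 percentage points lower from compound 1 to compound 4 (within the scatter), again within the scatter, so neither the second chloro nor the phenyl on the core separates any pair of these compounds in this assay. Nothing available explains these readings or links them to any property of the groups.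

Going by these compounds, whether a group other than chloro on the carbonyl-bound phenyl, such as a methoxy, a nitrile or a carboxylic acid, would give a step beyond the scatter remains open, as does the effect of an amine or a longer chain on the shared core. All readings come from a single concentration, so the potency of these compounds at this receptor also remains open.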